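Methyl on the Tropone Ring of an Oxalamide Ester

The source may hold more compounds than are shown below. What is called first, only, known or untested is meant among the compounds shown, and "the series" means these compounds.

Compound 1 `CCOC(=O)C(=O)Nc1cccccc1=O` sets the high mark among the three measured compounds: in a functional assay on the whole organism (strain Sprague-Dawley CD) for inhibition, with Rattus norvegicus as the target, read by paw edema, at a dose of 30 mg/kg by the intraperitoneal route (a lower number here means a weaker effect, a higher number a stronger effect of the compound at the dose given), compound 1 gives 84%. Compound 2 `COC(=O)C(=O)Nc1ccc(OC)c(=O)cc1` gives 36%, and compound 3 `CCOC(=O)C(=O)Nc1ccccc(Oc2ccccc2)c1=O` gives 16%. Among the measured compounds shown here, the one step measured on a single change, a number 68 percentage points lower from compound 1 to compound 3 (beyond the scatter), shows that adding a group to this ring can cost a great deal. Compound 4 `CCOC(=O)C(=O)Nc1c(C)ccccc1=O` differs from compound 1 by methyl in place of hydrogen on an aromatic carbon. Methyl is far smaller than phenoxy, so the loss seen in the measured step is taken as an upper bound rather than a forecast. A moderate drop is expected, a number 24 percentage points lower from compound 1 to compound 4 (beyond the scatter), and compound 4 is therefore estimated to give 60% in this assay, within a range from 30% to 85%.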

Compound 4, a percentage reported as inhibition, in the whole organism at one dose (the size of the read-out at that dose, not a potency): 47%
For compound 4 the middle estimate is 13 percentage points above the measured one; the range from low to high includes it.
By their numbers in this assay, from the lowest: compound 3; then compound 2; then compound 4; then compound 1.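

At this position, next to the ring atom that bears a group of 8 heavy atoms, even methyl, which enters with only 1 heavy atom, is enough for a large change in this assay, with a number 37 percentage points lower from compound 1 to compound 4 (beyond the scatter). So a large loss does not require a group as big as phenoxy. No measurement here explains this loss, and its cause remains unknown. On these data alone, whether fluorine, an amine or a longer chain on this same carbon would keep more of the effect stays open. So does whether methyl elsewhere on the ring would cost as much.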